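The source may hold more compounds than are shown below. What is called first, only, known or untested is meant among the compounds shown, and "the series" means these compounds.

Measured in a physicochemical assay for lipophilicity; a higher number here means a more lipophilic compound, a lower number a more polar compound:
compound 1 `Cc1cn([C@H]2CCCN(S(=O)(=O)c3ccc(C(=O)O)c(Oc4cccc(Cl)c4)c3)C2)c(=O)[nH]c1=O`: -1.3
compound 2 `Cc1cccc(Oc2cc(S(=O)(=O)N3CCC[C@H](n4cc(C)c(=O)[nH]c4=O)C3)ccc2C(=O)O)c1`: -1.6

Within the data shown here, compound 2 stands at -1.6, within the scatter of compound 1 , the only other compound measured. Next comes compound 3 `Cc1cn([C@H]2CCCN(S(=O)(=O)c3ccc(C(=O)O)c(Oc4ccc(Cl)c(Cl)c4)c3)C2)c(=O)[nH]c1=O`, with 3,4-dichlorophenyl in place of 3-methylphenyl on an oxygen on an aromatic ring. Among the measured compounds shown here, one measured step bears on this: a number 0.30 log units lower from compound 1 to compound 2 (within the scatter), methyl in place of chloro on an aromatic carbon, within the scatter. It covers only part of the new change, which runs the opposite way, from methyl to chloro. In this assay a step beyond the scatter is expected, namely a number 0.80 log units higher from compound 2 to compound 3 (beyond the scatter). For compound 3 the estimate is -0.8, with an expected range from -1.2 to -0.4.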

Compound 3, distribution coefficient: -0.9
Beside the measured number, compound 3's estimate is 0.10 log units above it; measured number inside the range.
By their numbers in this assay, from the lowest: compounds 2 and 1 (each within the scatter of the next); then compound 3.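

In this assay, the group on the oxygen now moves the number beyond the scatter: 3,4-dichlorophenyl in place of 3-methylphenyl gives a number 0.70 log units higher from compound 2 to compound 3 (beyond the scatter), whereas the earlier methyl in place of chloro did not. A single change, chloro in place of hydrogen on an aromatic carbon, is enough to pass the scatter, giving a number 0.40 log units higher from compound 1 to compound 3 (beyond the scatter). No measurement at hand accounts for either step.

Open, as far as these compounds go, is how an amine or a methoxy group on this aromatic ring would read in this assay. Also open, from the compounds shown here alone, is whether a third chloro would add a further step.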